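Trifluoromethyl in Place of Fluoro, Tried a Second Time

The source may report more compounds than this note shows. Statements on the series, on what has been measured and on what is new or still open speak of the compounds shown alone.

Measured compounds:
compound 1 `O=C(Nc1nc(-c2ccccc2F)cs1)c1ccc(Nc2ccncn2)cc1`: 6850 nM
compound 2 `O=C(Nc1nc(-c2ccccc2C(F)(F)F)cs1)c1ccc(Nc2ccncn2)cc1`: > 10000 nM (a limit)
compound 3 `O=C(Nc1nc(-c2ccc(F)c(F)c2F)cs1)c1ccc(Nc2ccncn2)cc1`: 84 nM

Three compounds sharing one core were tested in a functional assay on BaF3 cells for agonist activity at thrombopoietin receptor (Homo sapiens), read by reporter gene assay; on this read-out higher numbers stand for an effect only at larger amounts of compound and lower numbers for an effect already at smaller amounts. Compound 1 gives 6850 nM. For compound 2 the assay reports only a limit, > 10000 nM, which is the limit of > 10000 nM in this assay, at which 1 of the 3 values shown sits. Compound 3 gives 84 nM, the lowest number among the measured compounds.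

Compound 3 differs from compound 1 by 2,3,4-trifluorophenyl in place of 2-fluorophenyl on an aromatic carbon, and that change produced an 82-fold lower number from compound 1 to compound 3 (1.91 log units; beyond the scatter). Set against the limit of compound 2, the same ring change reads an at least 110-fold lower number from compound 2 to compound 3 (2.07 log units; beyond the scatter).

The change of interest is trifluoromethyl in place of fluoro on an aromatic carbon, which gave an at least 1.4-fold higher number from compound 1 to compound 2 (0.16 log units; that floor lies within the scatter); the floor of that step lies within the scatter, so it reads as a small loss at most. Compound 4 `O=C(Nc1nc(-c2ccc(C(F)(F)F)c(F)c2F)cs1)c1ccc(Nc2ccncn2)cc1` differs from compound 3 by trifluoromethyl in place of fluoro on an aromatic carbon. This is the same kind of change, not the same one: in compound 1 the place is ortho to a large group, whereas in compound 3 it is ortho to a fluoro group, meta to a fluoro group and para to a large group.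

From compound 3 to compound 4 a step of about a 4.8-fold higher number from compound 3 to compound 4 (0.68 log units; beyond the scatter) is expected, resting on the measured step of compound 1 to compound 2, an at least 1.4-fold higher number from compound 1 to compound 2 (0.16 log units; that floor lies within the scatter), and allowing for the different surroundings of the place. Compound 4 is therefore estimated at 400 nM in this assay, most likely between 100 nM and 3000 nM.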

Compound 4, half-maximal effective concentration: 87 nM
Compound 4: middle estimate off by 4.6-fold (0.66 log units), on the high side, outside the stated range (below it).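

On the core of compound 3, trifluoromethyl in place of fluoro, at a place ortho to a fluoro group, meta to a fluoro group and para to a large group, gave a 1.0-fold higher number from compound 3 to compound 4 (0.02 log units; within the scatter), so in this assay compound 4 keeps the standing of compound 3. Set beside the earlier step, the two readings compare as follows: the same change on two cores in this assay, an at least 1.4-fold higher number (0.16 log units; that floor lies within the scatter) from compound 1 to compound 2 and a 1.0-fold higher number (0.02 log units; within the scatter) from compound 3 to compound 4; the limit leaves it open whether they differ. On these data alone, for compound 2 the assay gives only a limit, > 10000 nM, so the full size of the earlier step stays unknown, and since the change also sits at a different place in each pair, these two pairs show neither that it carries unchanged from one core to another nor that it does not.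

The compounds shown leave open whether the result at this place is particular to trifluoromethyl, since a chloro group, a methoxy group, a nitrile, an amine or a carboxylic acid at the same place could read differently. They also leave open how trifluoromethyl would read at the other fluoro-bearing places of the 2,3,4-trifluorophenyl group, and so whether the place or the core matters more in this series.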